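The source may hold more compounds than are shown below. What is called first, only, known or untested is meant among the compounds shown, and "the series" means these compounds.

The two measured compounds:

Compound 1, `O=C(CCCCC1CCSS1)NCc1cn(CCCCOc2ccc3ccc(=O)oc3c2)nn1`: 45.9%
Compound 2, `O=C(CCCCC1CCSS1)NCc1cn(CCCCOc2ccc3cc(-c4ccccc4)c(=O)oc3c2)nn1`: 34.8%

Within the data shown here, in a functional assay on PC-12 cells (Rattus norvegicus) for cytotoxicity, read by MTT assay, with stated times of 3 h and 2 h, tested at 1 uM (a lower number here means a weaker effect, a higher number a stronger effect of the compound at the concentration tested), compound 2 stands lowest of the two numbers so far; its nearest neighbour is compound 1, which lies higher by the step of a number 11.1 percentage points lower from compound 1 to compound 2 (beyond the scatter). Compound 3, `COc1ccc(-c2cc3ccc(OCCCCn4cc(CNC(=O)CCCCC5CCSS5)nn4)cc3oc2=O)cc1`, differs from compound 2 in one place: methoxy in place of hydrogen on an aromatic carbon. Among the measured compounds shown here, the only measured step, a number 11.1 percentage points lower from compound 1 to compound 2 (beyond the scatter), concerns a different change, the entry of the phenyl group itself, and so bears on the present change only loosely. For the measured compounds named here, no measured pair shows what a methoxy group added to that phenyl does in this assay. With that little to go on, the expected step is small and on the lower side, and the estimated step of a number 3.8 percentage points lower from compound 2 to compound 3 (within the scatter) is expected to lie within the scatter. Compound 3 is therefore expected to give about 31%, estimated between 18% and 44%.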

Compound 3, a percentage reported as activity, at one concentration (the size of the read-out at that concentration, not a potency): 36.8%
Beside the measured number, compound 3's estimate is 5.8 percentage points below it; low and high end bracket the measured number.
By their numbers in this assay, from the lowest: compounds 2, 3 and 1 (each within the scatter of the next, the first and the last beyond it).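

In this assay, adding a methoxy group to the phenyl ring does not separate the two compounds: the result is a number 2 percentage points higher from compound 2 to compound 3 (within the scatter). The 4-methoxyphenyl group in place of hydrogen gives a number 9.1 percentage points lower from compound 1 to compound 3 (within the scatter), whereas the phenyl group gave a number 11.1 percentage points lower from compound 1 to compound 2 (beyond the scatter), but this contrast does not set the two groups apart, since the methoxy step between them lies within the scatter. Nothing measured for these compounds explains the result.

On these data alone, it remains open whether a different group on the same ring, such as an amine or a carboxylic acid, would give a step beyond the scatter. The compounds shown also leave open whether a methoxy group elsewhere on that ring would read the same, and whether these readings would hold at other concentrations.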